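The source may report more compounds than this note shows. Statements on the series, on what has been measured and on what is new or still open speak of the compounds shown alone.

Measured compounds in a functional assay on A549 cells (Homo sapiens) for antiproliferative activity, read by MTT assay, with a stated time of 48 h; on this read-out higher numbers stand for weaker inhibition and lower numbers for stronger inhibition:
compound 1 `N#CC1=C(N)Oc2c(c3nc4ccccc4nc3c3ccccc23)C12C(=O)N(Cc1cnnn1-c1ccc(Br)cc1)c1ccccc12` — compound 1 gives 44300 nM
compound 2 `N#CC1=C(N)Oc2c(c3nc4ccccc4nc3c3ccccc23)C12C(=O)N(Cc1cnnn1-c1cccc(Br)c1)c1ccccc12` — compound 2 reaches only a limit of the assay, > 50000 nM
compound 3 `CCOc1ccc(-n2nncc2CN2C(=O)C3(C(C#N)=C(N)Oc4c(N)cc5nc6ccccc6nc5c43)c3ccccc32)cc1` — compound 3 reaches only a limit of the assay, > 50000 nM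

Compound 3 therefore stands at the ceiling of this assay, with no number of its own; it shares that position with compound 2, as the limit of > 50000 nM in this assay, at which 2 of the 3 values shown sit, records. Among the measured compounds shown here, compound 1 is the only compound of the three with a numeric read-out, and that number is itself weak.

For the measured compounds named here, the single measured step, an at least 1.1-fold higher number from compound 1 to compound 2 (0.05 log units; that floor lies within the scatter), concerns a shift of the bromine on the aryl ring and does not touch the change now in question; its size in any case lies within the scatter. Going by the values given here, no measured step addresses a swap of the whole aryl group on the triazole nitrogen.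

Compound 4 `N#CC1=C(N)Oc2c(N)cc3nc4ccccc4nc3c2C12C(=O)N(Cc1cnnn1-c1ccc(Cl)cc1[N+](=O)[O-])c1ccccc12` differs from compound 3 by 4-chloro-2-nitrophenyl in place of 4-ethoxyphenyl on an aromatic nitrogen. With compound 3 at a limit and compound 1 only just inside the measurable range, compound 4 is expected to show no step beyond the scatter, a step that the limit leaves unreadable from compound 3 to compound 4, and most likely to return a limit again. The estimate for compound 4 in this assay is 55000 nM, expected between 25000 nM and 120000 nM.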

Compound 4, half-maximal inhibitory concentration: > 50000 nM
Compound 4: no number, only a limit; the forecaster's own chance of this, stated with the estimate: 60%; the middle value is on the limit's open side.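

In this assay compound 4 gives > 50000 nM, a limit and not a number. Compound 3 also stands at a limit, so no step can be read between compound 3 and compound 4. The compounds shown leave open how 4-chloro-2-nitrophenyl and 4-ethoxyphenyl on the aromatic nitrogen compare, with the series largely at one value: the limit of > 50000 nM in this assay, at which 3 of the 4 values shown sit.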